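The compounds below may be only part of what the source reports. "The series", "measured", "known", "first", "only" and "open" are said of these compounds alone.

Measured so far in a functional assay on OE19 cells (Homo sapiens) for cytotoxicity, read by MTT assay, with a stated time of 48 h; a lower number here means a stronger inhibitor, a higher number a weaker inhibitor:
compound 1 `CC1(C)[C@H](C(=O)OC(c2ccccc2)c2ccccc2)N2C(=O)/C(=C/C(=O)c3ccc([N+](=O)[O-])cc3)[C@H]2[S+]1[O-]` gives 92400 nM
compound 2 `CC1(C)S[C@@H]2/C(=C\C(=O)c3ccc(Cl)cc3)C(=O)N2[C@H]1C(=O)OC(c1ccccc1)c1ccccc1` gives 14600 nM

Compound 2 holds the lowest of the two numbers; the nearest, compound 1, sits a good way higher, beyond the scatter. For the measured compounds named here, compound 1 and compound 2 differ in more than one place, so only their two values are known here, no single step between them.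

Compound 3 `CC1(C)S[C@@H]2/C(=C\C(=O)c3ccc([N+](=O)[O-])cc3)C(=O)N2[C@H]1C(=O)OC(c1ccccc1)c1ccccc1` is not yet measured. It differs from compound 2 as nitro in place of chloro on an aromatic carbon. With no shown step for this change, the expected step of a 2.1-fold higher number from compound 2 to compound 3 (0.31 log units; beyond the scatter) is a modest weakening, perhaps not beyond the scatter. Compound 3 is estimated at 30000 nM, within 10000 nM to 90000 nM.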

Compound 3, half-maximal inhibitory concentration: 44100 nM
The estimate for compound 3 lay 1.5-fold (0.17 log units) below the measured number, within the range that was stated.
By their numbers in this assay, from the lowest: compound 2; then compound 3; then compound 1.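

In this assay the 4-chlorophenyl to 4-nitrophenyl change gives the series its first single-place step, a 3.0-fold higher number from compound 2 to compound 3 (0.48 log units; beyond the scatter) with the rest of the structure held constant. At this aromatic carbon, para to a large group, the substituent therefore affects the read-out: the step is modest but beyond the scatter, with chloro giving the lower number. No available data bear on the reason for this step.

The compounds shown leave open how an amine or a methoxy group on this carbon would read. With only chloro and nitro at this place, no trend across substituents can be drawn.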